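Cyclopropylcarbonyl for Acetyl on a Benzothiazole Amide

The source may hold more compounds than are shown below. What is called first, only, known or untested is meant among the compounds shown, and "the series" means these compounds.

Measured compounds:
Compound 1 `COc1c(NS(=O)(=O)c2ccc(F)cc2)cc(-c2ccc3nc(NC4CC4)sc3n2)cc1C(N)=O` — in a functional assay on A549 cells (Homo sapiens) for antiproliferative activity, read by MTT assay, with a stated time of 72 h (a higher number here means a weaker inhibitor, a lower number a stronger inhibitor), compound 1 gives 30300 nM
Compound 2 `COc1c(NS(=O)(=O)c2ccc(F)cc2)cc(-c2ccc3nc(NC(C)=O)sc3c2)cc1C(N)=O` — in this assay compound 2 gives 1700 nM
Compound 3 `COc1c(NS(=O)(=O)C2CC2)cc(-c2ccc3nc(NC(C)=O)nn3c2)cc1C(N)=O` — in this assay compound 3 gives "not determined" (no result reported), that is, no result is reported for it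

Going by the values given here, compound 2 holds the lowest of the two numbers available; the only neighbour with a number, compound 1, stands a long way higher, well beyond the scatter of repeated measurements, while compound 3 adds no number at all. Compound 4 `COc1c(NS(=O)(=O)c2ccc(F)cc2)cc(-c2ccc3nc(NC(=O)C4CC4)sc3c2)cc1C(N)=O` is not yet measured. Among the compounds with values here, its single difference from compound 2 is cyclopropyl in place of methyl on a carbonyl carbon, so that the acetamido of compound 2 becomes a (cyclopropylcarbonyl)amino. Within the data shown here, no pair of measured compounds shows what this change does in this assay; it is small in the count of atoms, and on that basis the account expects a step of no more than about the scatter, if anything a modest move toward a lower number, as a 1.4-fold lower number from compound 2 to compound 4 (0.15 log units; within the scatter) expresses. Compound 4 is therefore estimated at 1200 nM, with a likely range from 400 nM to 4000 nM.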

Compound 4, half-maximal inhibitory concentration: 6340 nM
The estimate for compound 4 lay 5.3-fold (0.72 log units) below the measured number; measured number outside the range, above it.
By their numbers in this assay, from the lowest: compound 2; then compound 4; then compound 1.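

Going by these compounds alone, this is the first measured step at this position, and it shows that the position is sensitive to what sits on the carbonyl carbon. In this assay, cyclopropyl in place of methyl gives a 3.7-fold higher number from compound 2 to compound 4 (0.57 log units; beyond the scatter) and so moves toward a weaker inhibitor, leaving the acetamido of compound 2 ahead of the (cyclopropylcarbonyl)amino of compound 4. The compounds shown offer no measurement that accounts for this step.

On these data alone, whether an ethyl or a cyclobutyl on the same carbonyl carbon would behave like the methyl or like the cyclopropyl remains open, as does the effect of a chain ending in an amine. The change is also seen in this one pair only, so whether it would hold on another core, such as that of compound 1, cannot be said.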